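A few compounds are considered here, and "the series" means these few. Any claim that something is new, unique, unknown or untested is made for them only; others in the source may bear on it.

Compound 1 `Nc1sc(-c2ccc(Cl)cc2)c(-c2ccc(Cl)cc2)c1C(=O)NC1CC1` is the starting point. In a functional assay on PC-3 cells (Homo sapiens) for cytotoxicity, read by sulforhodamine B assay, with a stated time of 72 h (a higher number here means a weaker inhibitor, a lower number a stronger inhibitor), compound 1 gives 3680 nM. Compound 2 `Nc1sc(-c2ccc(Cl)cc2)c(-c2ccc(Cl)cc2)c1C(=O)N1CCCC1` carries a pyrrolidin-1-yl group on the carbonyl carbon where compound 1 has cyclopropylamino, and in this assay compound 2 gives 6220 nM. Among the measured compounds shown here, the step of a 1.7-fold higher number from compound 1 to compound 2 (0.23 log units; within the scatter) lies within the scatter, so on the numbers so far compound 2 sits alongside compound 1, with nothing to separate the two.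

Compound 3 `Nc1sc(-c2ccc(Br)cc2)c(-c2ccc(Cl)cc2)c1C(=O)N1CCCC1` differs from compound 2 by a single swap: bromo in place of chloro on an aromatic carbon. For the measured compounds named here, no measured step touches this position; the one step known, a 1.7-fold higher number from compound 1 to compound 2 (0.23 log units; within the scatter), concerns the amide end and itself stays within the scatter. Nothing therefore points to a movement beyond the scatter in this assay, in either direction. The change is expected to amount to a 1.0-fold lower number from compound 2 to compound 3 (0.02 log units; within the scatter). Compound 3 is thus estimated at 6000 nM, with a range from 2500 nM to 15000 nM.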

Compound 3, half-maximal inhibitory concentration: 37500 nM
For compound 3 the middle estimate is 6.3-fold (0.80 log units) below the measured one, outside the stated range (above it).
By their numbers in this assay, from the lowest: compounds 1 and 2 (each within the scatter of the next); then compound 3.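

In this assay, changing 4-chlorophenyl to 4-bromophenyl gives a 6.0-fold higher number from compound 2 to compound 3 (0.78 log units; beyond the scatter), making compound 3 the weaker inhibitor. This position is therefore sensitive to a very small edit: one halogen atom replaces another, no ring, hydrogen-bond donor, hydrogen-bond acceptor or net charge enters or leaves, and the change still exceeds the scatter, which the earlier step at the amide end did not. No measurement at hand explains why this swap weakens the compound.

The compounds shown leave open whether any group other than chloro works here, such as fluoro, methoxy or an amine, and whether the same swap on the other 4-chlorophenyl group would act alike. Going by these compounds, it is also open whether bromo would have the same effect with cyclopropylamino on the carbonyl carbon, as in compound 1.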